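Amino group and half-life in the cycloalkyl series

The source may hold more compounds than are shown below. What is called first, only, known or untested is meant among the compounds shown, and "the series" means these compounds.

- Compound 1 `Nc1ncnc2c1c(Oc1cc(C(F)(F)F)ccn1)nn2[C@H]1CC[C@@H](N)CC1`: > 2.41 h (a limit of the assay)
- Compound 2 `Nc1ncnc2c1c(Oc1cc(C(F)(F)F)ccn1)nn2C1CCCCC1`: 0.55 h

Among the compounds with values here, in an ADME assay on microsomes from liver (Homo sapiens) for metabolic stability, read by LC-MS, using NADPH, with a stated time of 10 min, tested at 10 uM (a lower number here means that the compound disappears faster, a higher number that the compound lasts longer), compound 2 gives the only actual number, 0.55 h. The reading for compound 1 is a limit: the limit of > 2.41 h in this assay, at which 1 of the 2 values shown sits.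

Compound 3 `Nc1ncnc2c1c(Oc1cc(C(F)(F)F)ccn1)nn2[C@@H]1CC[C@H](N)C1` is not yet measured. Relative to compound 2, it has 3-aminocyclopentyl in place of cyclohexyl on an aromatic nitrogen.

Within the data shown here, one measured step bears on this change, with hydrogen in place of amino on a saturated ring carbon: an at least 4.3-fold lower number from compound 1 to compound 2 (0.64 log units; beyond the scatter). That step lies beyond the scatter, and compound 3 carries an amino group again, so a move of similar size in the opposite direction is expected in this assay. Among the measured compounds shown here, no measured step covers the change of ring size.

The estimated step is a 4.0-fold higher number from compound 2 to compound 3 (0.60 log units; beyond the scatter). For compound 3 the expected half-life is 2.2 h, with an estimated range of 1 h to 4.5 h.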

Compound 3, half-life: > 2.41 h
Compound 3: no number, only a limit; the forecaster's own chance of this, stated with the estimate: 45%; at least 1.0-fold (0.03 log units) between middle value and limit.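

In this assay, 3-aminocyclopentyl in place of cyclohexyl on an aromatic nitrogen gives an at least 4.3-fold higher number from compound 2 to compound 3 (0.64 log units; beyond the scatter). The earlier step showed this kind of difference only with 4-aminocyclohexyl; here a five-membered ring with an amino group also stands clear of the unsubstituted cyclohexyl of compound 2. Compound 1 and compound 3 both give only a limit, so the step between them cannot be read and the two ring sizes cannot be ranked: the limit of > 2.41 h in this assay, at which 2 of the 3 values shown sit.

From the compounds shown here alone, how far either amine-bearing compound lies past that limit stays open. Also open, going by these compounds, is how much of the difference belongs to the amino group and how much to the ring size, which a plain cyclopentyl, or a hydroxyl or dimethylamino group on the five-membered ring, would help to separate.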